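Para-substituted anilines on a shared nitrile core

The compounds below may be only part of what the source reports. "The series", "measured", "known", "first", "only" and "open" are said of these compounds alone.

Measured compounds:
compound 1 `CC(C)c1ccc(-c2nc(SCc3cn(CC(=O)NC(=O)Nc4ccccn4)nn3)nc(Nc3cccc([N+](=O)[O-])c3)c2C#N)cc1` — 26400 nM
compound 2 `COc1ccc(Nc2nc(SCc3cn(CC(=O)NC(=O)Nc4ccccn4)nn3)nc(-c3ccc(C(C)C)cc3)c2C#N)cc1` — 360 nM
compound 3 `CC(C)c1ccc(-c2nc(SCc3cn(CC(=O)NC(=O)Nc4ccccn4)nn3)nc(Nc3ccccc3O)c2C#N)cc1` — 16100 nM

In a functional assay on B16-F10 cells (Mus musculus) for inhibition, read by MTT assay, with a stated time of 72 h (a lower number here means a stronger inhibitor, a higher number a weaker inhibitor), compound 1 gives the highest number of the three shown; compound 3 lies within the scatter of it, while compound 2 sits far lower. The steps that matter are a 73-fold lower number from compound 1 to compound 2 (1.87 log units; beyond the scatter), a large step, and a 1.6-fold lower number from compound 1 to compound 3 (0.21 log units; within the scatter), which stays within the scatter. Compound 4 `CC(C)c1ccc(Nc2nc(SCc3cn(CC(=O)NC(=O)Nc4ccccn4)nn3)nc(-c3ccc(C(C)C)cc3)c2C#N)cc1` differs from compound 1 in one place: 4-isopropylphenyl in place of 3-nitrophenyl on a nitrogen on an aromatic ring. Within the data shown here, no measured step covers this exact change, and the data hold no other 4-isopropylphenyl on that nitrogen. Because a 73-fold lower number from compound 1 to compound 2 (1.87 log units; beyond the scatter) shows that moving away from 3-nitrophenyl can lower the number greatly, a step downward beyond the scatter is expected for compound 4, though smaller and less certain. Compound 4 is thus estimated at 2000 nM, between 300 nM and 15000 nM, an expected step of a 13-fold lower number from compound 1 to compound 4 (1.12 log units; beyond the scatter).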

Compound 4, half-maximal inhibitory concentration: 4380 nM
Beside the measured number, compound 4's estimate is 2.2-fold (0.34 log units) below it; low and high end bracket the measured number.
By their numbers in this assay, from the lowest: compound 2; then compound 4; then compounds 3 and 1 (each within the scatter of the next).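

In this assay, 4-isopropylphenyl on this nitrogen gives a 6.0-fold lower number from compound 1 to compound 4 (0.78 log units; beyond the scatter) against 3-nitrophenyl and a 3.7-fold lower number from compound 3 to compound 4 (0.57 log units; beyond the scatter) against 2-hydroxyphenyl, so a group with no hydrogen-bond acceptors can also lower the number. It does not match 4-methoxyphenyl, however: a 12-fold higher number from compound 2 to compound 4 (1.09 log units; beyond the scatter) for isopropyl in place of methoxy on an aromatic carbon shows that the group at this one aromatic carbon matters greatly. As far as these compounds go, whether a 4-aminophenyl or 4-carboxyphenyl group would fall below compound 2 remains open. No evidence here accounts for these steps.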